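Two double bonds in the decyl chain of compound 3

The compounds below may be only part of what the source reports. "The series", "measured", "known", "first", "only" and "open" are said of these compounds alone.

Compound 1 `CCOCCOCCOCCOc1ccccc1C(SCCC(=O)O)SCCC(=O)O`: in an assay on membranes from lung (Cavia porcellus) for binding affinity to cysteinyl leukotriene receptor (Homo sapiens) (on this read-out higher numbers stand for weaker inhibition and lower numbers for stronger inhibition), compound 1 gives > 20000 nM, which is a limit of the assay rather than a number (the limit of > 20000 nM in this assay, at which 1 of the 3 values shown sits).
Compound 2 `CCCCCCCCCCCCCOc1cccc(C(SCCC(=O)O)SCCC(=O)O)c1`: in this assay compound 2 gives 530 nM.
Compound 3 `CCCCCCCCCCCOc1cccc(C(SCCC(=O)O)SCCC(=O)O)c1`: in this assay compound 3 gives 78 nM.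

Among the numbers shown, compound 3 stands lowest; its nearest neighbour is compound 2, and the step of a 6.8-fold lower number from compound 2 to compound 3 (0.83 log units; beyond the scatter) separates them. Compound 4 `CCCCC/C=C/C/C=C/COc1cccc(C(SCCC(=O)O)SCCC(=O)O)c1` differs from compound 3 by deca-1,4-dien-1-yl in place of decyl on a saturated chain carbon bound to an oxygen on an aromatic ring. Within the data shown here, the only measured step, the one from compound 2 to compound 3, concerns the length of the chain and not the presence of double bonds, so it bears on the new change only loosely: it shows that the chain on the ether oxygen matters for the number, but not in which direction two double bonds would move it. The expectation is therefore a step of a 1.2-fold higher number from compound 3 to compound 4 (0.06 log units; within the scatter) that stays close to the scatter. Compound 4 is estimated at 90 nM, with a range from 25 nM to 320 nM.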

Compound 4, inhibition constant: 187 nM
Compound 4: middle estimate off by 2.1-fold (0.32 log units), on the low side; low and high end bracket the measured number.
By their numbers in this assay, from the lowest: compound 3; then compound 4; then compound 2. At a limit, above all of these: compound 1.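

In this assay, deca-1,4-dien-1-yl in place of decyl keeps the carbon count of the chain and adds two double bonds, and this gives a 2.4-fold higher number from compound 3 to compound 4 (0.38 log units; beyond the scatter). The chain on the oxygen therefore matters for more than its length, the only feature that differed in the earlier step: at equal carbon count, the unsaturated chain gives weaker inhibition, though the loss is modest. Nothing shown here explains why the double bonds move the number in this direction.

The compounds shown leave open whether a single double bond would give a similar step, or whether both are needed. They also leave open how a shorter chain, or a chain ending in an amine or a carboxylic acid, would behave at this position.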